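The source may hold more compounds than are shown below. What is called first, only, known or untested is meant among the compounds shown, and "the series" means these compounds.

Compound 1 `Nc1ncnc2c1c(-c1cnc3[nH]ccc3c1)nn2CCCCCCCCC(=O)NO`: 18900 nM
Compound 2 `Nc1ncnc2c1c(-c1cnc3[nH]ccc3c1)nn2CCCCCCCCCC(=O)NO`: 42100 nM

Within the data shown here, in a functional assay on Bel-7402 cells (Homo sapiens) for inhibition, read by MTT assay, with a stated time of 72 h (on this read-out lower numbers stand for stronger inhibition and higher numbers for weaker inhibition), compound 2 gives 42100 nM, the higher of the two numbers and so the weaker inhibition, with compound 1 as its only neighbour at 18900 nM. Compound 3 `Nc1ncnc2c1c(-c1cnc3[nH]ccc3c1)nn2CCCCCCC(=O)NO` has not been measured yet. It keeps the shared core and shortens the chain that ends in the hydroxycarbamoyl group: hydroxycarbamoyl in place of 3-(hydroxycarbamoyl)propyl on a saturated chain carbon, six bonds along the chain from an aromatic nitrogen. In words, hydroxycarbamoyl takes the place of 3-(hydroxycarbamoyl)propyl on a saturated chain carbon, six bonds along the chain from an aromatic nitrogen.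

Among the measured compounds shown here, only one measured step bears on this change: a 2.2-fold higher number from compound 1 to compound 2 (0.35 log units; beyond the scatter). That step is modest but beyond the scatter, and it lengthens the chain. Compound 3 moves the opposite way and further, so a lower number is expected. A single step cannot show whether the trend continues over a shorter chain, so the expectation stays loose. The estimated step is a 4.2-fold lower number from compound 2 to compound 3 (0.62 log units; beyond the scatter). For compound 3 the estimated value is 10000 nM, with an expected range from 3000 nM to 30000 nM.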

Compound 3, half-maximal inhibitory concentration: 30800 nM
The estimate for compound 3 lay 3.1-fold (0.49 log units) below the measured number, outside the stated range (above it).
By their numbers in this assay, from the lowest: compounds 1, 3 and 2 (each within the scatter of the next, the first and the last beyond it).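

In this assay, shortening the chain does not carry the earlier trend forward in any clear way: the change gives a 1.4-fold lower number from compound 2 to compound 3 (0.14 log units; within the scatter), and the comparison with the middle chain gives a 1.6-fold higher number from compound 1 to compound 3 (0.21 log units; within the scatter), so both steps stay within the usual scatter and compound 3 cannot be separated from either neighbour. Among these compounds, the only step beyond the scatter remains a 2.2-fold higher number from compound 1 to compound 2 (0.35 log units; beyond the scatter), so these three compounds show no steady rise of the number with chain length, and compound 3, with the shortest chain, goes against such a rise by matching compound 2, with the longest, within the scatter. Nothing available here explains why the numbers fall as they do.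

Going by these compounds, it remains open whether a still shorter chain or a longer chain than that of compound 2 would move the number clearly beyond the scatter. On these data alone, it is equally open how the shared core and chain would behave with a carboxylic acid or a primary amide at the chain end in place of the hydroxycarbamoyl group.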